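The source may report more compounds than this note shows. Statements on the series, on what has been measured and on what is new or still open speak of the compounds shown alone.

Measured compounds in a functional assay on A-375 cells (Homo sapiens) for cytotoxicity, read by MTT assay, with a stated time of 72 h, tested at 3 uM; a higher number here means more inhibition of growth at the concentration tested, a lower number less inhibition of growth:
Compound 1 `Cc1ccnc(/C(N)=N/NC(=S)N2CCSCC2)c1` gives 67.2%.
Compound 2 `N/C(=N\NC(=S)N1CCCCC1)c1ccccn1` gives 86.5%.

Compound 2 stands highest of the two numbers; the nearest is compound 1, whose value is lower by a gap beyond the scatter, though the two structures differ in more than one place. Compound 3 `Cc1ccnc(/C(N)=N/NC(=S)N2CCCCC2)c1` differs from compound 2 by methyl in place of hydrogen on an aromatic carbon. With no single-change comparison available, compound 3 is expected to sit close to compound 2, with a step of a number 8.5 percentage points lower from compound 2 to compound 3 (within the scatter) that stays within the scatter. Compound 3 is estimated at 78%, in a range from 60% to 92%.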

Compound 3, percent growth inhibition at one concentration: 69.5%
Beside the measured number, compound 3's estimate is 8.5 percentage points above it; the measured number falls inside the stated range.
By their numbers in this assay, from the lowest: compounds 1 and 3 (each within the scatter of the next); then compound 2.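

In this assay, methyl in place of hydrogen on the aromatic carbon opposite the ring nitrogen gives a number 17 percentage points lower from compound 2 to compound 3 (beyond the scatter), the first single-change reading showing that this position responds to substitution. With that methyl present, piperidin-1-yl in place of thiomorpholin-4-yl on the thiocarbonyl carbon gives a number 2.3 percentage points higher from compound 1 to compound 3 (within the scatter), so this exchange shows no clear difference. Nothing available explains either step. On these data alone, whether an ethyl, a methoxy or a chlorine at the same position would behave like methyl remains open. So does whether the two rings on the thiocarbonyl carbon would also match without the methyl.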